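A few compounds are considered here, and "the series" means these few. Any claim that something is new, unique, unknown or untested is made for them only; others in the source may bear on it.

Measured so far in a physicochemical assay for solubility, at pH 7.2; on this read-out lower numbers stand for lower solubility and higher numbers for higher solubility:

compound 1, `COc1c(/C=C/c2ccc(NS(C)(=O)=O)cc2)cc(N2CCC(=O)NC2=O)cc1C(C)(C)C`, gives 10300 nM
compound 2, `COc1c(CCc2ccc(NS(C)(=O)=O)cc2)cc(N2CCC(=O)NC2=O)cc1C(C)(C)C`, gives 18800 nM
compound 3, `COc1c(NC(=O)c2ccc(NS(C)(=O)=O)cc2)cc(N2CCC(=O)NC2=O)cc1C(C)(C)C`, gives 32800 nM

All three share one core and differ only in the linker that joins the two aromatic rings. Compound 1 has the lowest of the three numbers. Compound 2 lies close to it, within the usual scatter of repeated measurements, so no order between the two can be claimed. Compound 3 lies beyond the scatter and shows a higher solubility than compound 1.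

Compound 4, `COc1c(/C=C/c2ccc(NS(C)(=O)=O)cc2)cc(-n2ccc(=O)[nH]c2=O)cc1C(C)(C)C`, has not yet been measured. It keeps the linker of compound 1 and changes the ring that hangs from the core: a group of 8 heavy atoms (4 carbon, 2 nitrogen, 2 oxygen; one six-membered aromatic ring with 2 hetero atoms) in place of a group of 8 heavy atoms (4 carbon, 2 nitrogen, 2 oxygen; one six-membered non-aromatic ring with 2 hetero atoms), on an aromatic carbon. Among the measured compounds shown here, no measured pair shows this change, so there is no measured step to lean on. The ring that leaves and the ring that enters have the same count of heavy atoms and one hydrogen-bond donor each, so only a small step is expected, most likely within the scatter, with a slight lean toward a lower number. Compound 4 is expected to give 7000 nM, with a range from 2500 nM to 20000 nM. The step of a 1.5-fold lower number from compound 1 to compound 4 (0.17 log units; within the scatter) is thus expected to stay within the scatter.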

Compound 4, solubility: 20700 nM
For compound 4 the middle estimate is 3.0-fold (0.47 log units) below the measured one, outside the stated range (above it).
By their numbers in this assay, from the lowest: compounds 1, 2, 4 and 3 (each within the scatter of the next, the first and the last beyond it).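

In this assay the exchange of the non-aromatic ring for the aromatic ring with the same 8 heavy atoms, on the aromatic carbon para to a methoxy group, gives a 2.0-fold higher number from compound 1 to compound 4 (0.30 log units; within the scatter) and so allows no order between the two rings to be claimed. Among the compounds shown here, this is the first measured view of this position, since compound 1, compound 2 and compound 3 all carry the same non-aromatic ring and differ only in the linker. With the linker of compound 1 in place, the two rings therefore cannot be told apart on this read-out, although the step sits at the edge of the usual scatter and repeat measurements would be needed to refine it. Nothing available here accounts for the size of this step.

From the compounds shown here alone, whether the same ring exchange gives a similar step with the saturated two-carbon linker of compound 2 or the amide linker of compound 3 stays open, as only the linker of compound 1 is seen with both rings. Also open, going by these compounds, is how a quite different group on this aromatic carbon, such as a carboxylic acid, a morpholine ring or an open-chain urea, would compare with these two rings.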